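Swapping a Nitro Group for Chloro on a Hydrazone

A few compounds are considered here, and "the series" means these few. Any claim that something is new, unique, unknown or untested is made for them only; others in the source may bear on it.

Measured so far:
compound 1, `Cc1ccc(C(=O)N/N=C/c2ccc(Cl)cc2Cl)c(O)c1`: 9780 nM
compound 2, `Cc1ccc(C(=O)N/N=C/c2ccccc2[N+](=O)[O-])c(O)c1`: > 100000 nM

In a functional assay (Mus musculus, strain BALB/C) for inhibition, read by MTT assay, with stated times of 24 h and 72 h (a higher number here means a weaker inhibitor, a lower number a stronger inhibitor), compound 1 gives 9780 nM. Compound 2 is reported in this assay only as a limit, > 100000 nM, so no number is known for it. Going by the values given here, of the two values shown, compound 2 stands at the weaker end, at the limit of > 100000 nM in this assay, at which 1 of the 2 values shown sits, while compound 1 is the only one with a measured number.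

Compound 3, `Cc1ccc(C(=O)N/N=C/c2ccccc2Cl)c(O)c1`, has not yet been tested in this assay. It differs from compound 2 in one place: chloro in place of nitro on an aromatic carbon. Among the compounds with values here, no step between two measured compounds is available for this kind of change, and because compound 2 rests at the limit of > 100000 nM in this assay, at which 1 of the 2 values shown sits, the step can be bounded from one side only.

The change is expected to give an at least 3.3-fold lower number from compound 2 to compound 3 (0.52 log units; beyond the scatter), a move toward a stronger inhibitor whose size stays uncertain. Compound 3 is estimated at 30000 nM, expected to fall between 8000 nM and 150000 nM.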

Compound 3, half-maximal inhibitory concentration: 19200 nM
The estimate for compound 3 lay 1.6-fold (0.19 log units) above the measured number; measured number inside the range.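

In this assay, going by these compounds alone, putting chloro in place of nitro on an aromatic carbon, ortho to a large group, gives an at least 5.2-fold lower number from compound 2 to compound 3 (0.71 log units; beyond the scatter), the first sign that the group at this place matters for the read-out. That step gives only a minimum size, because the value of compound 2 is a limit and not a number: the limit of > 100000 nM in this assay, at which 1 of the 3 values shown sits. The new compound also links to compound 1, as hydrogen in place of chloro on an aromatic carbon gives a 2.0-fold higher number from compound 1 to compound 3 (0.29 log units; within the scatter), so the second chloro of compound 1 has no effect that can be told apart from the usual variation between repeated measurements.

The compounds shown leave open whether chloro itself helps or nitro itself hurts, since no compound here has plain hydrogen at this place, and an amine or a methoxy group there could separate the two readings. As far as these compounds go, the methyl and hydroxyl groups of the shared core are the same in all three compounds, so what they contribute to the read-out also remains unknown.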